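This account rests on a few compounds, and the source may have more. Where it says the series, first, only, none or still open, it means among the compounds named here.

Working notes on the series, all run in an assay on BaF3 cells for inhibition of proto-oncogene tyrosine-protein kinase receptor Ret (Homo sapiens), read by MTT assay, with a stated time of 48 h; on this read-out higher numbers stand for weaker inhibition of growth and lower numbers for stronger inhibition of growth. Compound 1 `CC(C)(O)Cn1nc(-c2cc(C3CC3)on2)c2c(N)ncnc21` gives 1770 nM in this assay, the lowest of the two numbers in hand. Compound 2 `CC(C)n1nc(/C=N/OCc2ccccc2)c2c(N)ncnc21` gives 7410 nM in this assay, a gap from compound 1 that lies beyond the scatter. Compound 3 `Cn1nc(-c2cc(C3CC3)on2)c2c(N)ncnc21` differs from compound 1 by hydrogen in place of 1-hydroxy-1-methylethyl on a saturated chain carbon bound to an aromatic nitrogen. Among the measured compounds shown here, no measured pair covers this change, so the direction is expected from the removal of the 1-hydroxy-1-methylethyl group alone: a modest weakening, around the edge of the scatter, is expected. Compound 3 is therefore estimated at 4000 nM, range 1500 nM to 12000 nM, an expected step of a 2.3-fold higher number from compound 1 to compound 3 (0.35 log units; beyond the scatter).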

Compound 3, concentration for 50% growth inhibition: 2670 nM
Estimate against measurement, compound 3: 1.5-fold (0.18 log units) above; low and high end bracket the measured number.
By their numbers in this assay, from the lowest: compounds 1 and 3 (each within the scatter of the next); then compound 2.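

In this assay, among the compounds shown here, replacing 2-hydroxy-2-methylpropyl with methyl gives a 1.5-fold higher number from compound 1 to compound 3 (0.18 log units; within the scatter) and is the first single-place comparison. At this position, on a saturated chain carbon bound to an aromatic nitrogen, removal of 1-hydroxy-1-methylethyl produces no change that can be told from the scatter. On these data alone, whether an amine, a carboxylic acid or a longer chain in this place would shift the number beyond the scatter remains open. No supporting data explain the closeness of the two numbers.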